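The source may hold more compounds than are shown below. What is called first, only, known or untested is meant among the compounds shown, and "the series" means these compounds.

Values in a functional assay on K562 cells (Homo sapiens) for cytotoxicity, read by thymidine incorporation, with a stated time of 48 h; on this read-out lower numbers stand for stronger inhibition and higher numbers for weaker inhibition:
- Compound 1 `O=C1Nc2c(ncn2Cc2ccccc2)C(C#Cc2ccccc2)N1Cc1ccccc1`: 0.8 ug/mL
- Compound 2 `O=C1Nc2c(ncn2Cc2ccccc2)C(C#CC2CC2)N1Cc1ccccc1`: 1.3 ug/mL
- Compound 3 `O=C1Nc2c(ncn2Cc2ccccc2)C(c2ccccc2)N1Cc1ccccc1`: 0.2 ug/mL

Compound 3 stands lowest of the three, and its steps to both others lie beyond the scatter. Compound 4 `CC1c2ncn(Cc3ccccc3)c2NC(=O)N1Cc1ccccc1` has not yet been measured. Its structural change from compound 3 is methyl in place of phenyl on a saturated ring carbon, in words methyl in place of phenyl on a saturated ring carbon.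

Among the measured compounds shown here, two measured steps bear on this change, since both end at the phenyl on that same carbon. They are a 4.0-fold lower number from compound 1 to compound 3 (0.60 log units; beyond the scatter) and a 6.5-fold lower number from compound 2 to compound 3 (0.81 log units; beyond the scatter), so each of the two groups tried there in place of phenyl gave a higher number. Those two groups themselves differ little, with a 1.6-fold higher number from compound 1 to compound 2 (0.21 log units; within the scatter). For the measured compounds named here, no measured compound carries methyl at this carbon, and three compounds make a thin basis, so the estimate stays wide. A modest step of similar size toward a higher number is expected, and the expected step is a 5.0-fold higher number from compound 3 to compound 4 (0.70 log units; beyond the scatter) in this assay. For compound 4 the estimated value is 1 ug/mL, with an expected range from 0.3 ug/mL to 4 ug/mL in this estimate.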

Compound 4, half-maximal inhibitory concentration: 1.4 ug/mL
Estimate against measurement, compound 4: 1.4-fold (0.15 log units) below; the measured number falls inside the stated range.
By their numbers in this assay, from the lowest: compound 3; then compounds 1, 2 and 4 (each within the scatter of the next).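

In this assay, replacing the phenyl on the saturated ring carbon with methyl, a group of one carbon and no ring, takes the number away from that of compound 3 (a 7.0-fold higher number from compound 3 to compound 4 (0.85 log units; beyond the scatter)), so a third, quite different group at this position also fails to match phenyl. Methyl does not separate from either ethynyl group (a 1.1-fold higher number from compound 2 to compound 4 (0.03 log units; within the scatter); a 1.8-fold higher number from compound 1 to compound 4 (0.24 log units; within the scatter)), so among these four compounds the lowest number belongs only to the compound with phenyl directly on that carbon, while compound 1, whose phenyl sits at the far end of the triple bond, stays with compound 2 and compound 4. The data offer no measurement that explains why phenyl directly on this carbon stands apart from the other three groups.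

The compounds shown leave open whether another ring directly on this carbon, such as pyridyl or cyclohexyl, or a phenyl bearing a methoxy group or chlorine, would keep the low number of compound 3. They also leave open how a bare hydrogen, an ethyl group or an amine-bearing chain would read at this position, and whether the two benzyl groups of the shared core matter to the result.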